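Fluoro for methoxy on a nitroaryl biaryl: expected cytotoxicity

This account rests on a few compounds, and the source may have more. Where it says the series, first, only, none or still open, it means among the compounds named here.

Measured so far:
compound 1, `COc1cc(CC(O)c2ccc(-c3ccc(CO)cc3)cc2)c([N+](=O)[O-])cc1OC`: > 244000 nM
compound 2, `COc1ccc(-c2ccc(C(O)Cc3cc(OC)c(OC)cc3[N+](=O)[O-])cc2)cc1`: > 244000 nM

In an ADME assay on HeLa Rh cells (Homo sapiens) for cytotoxicity, read by microscopy (a higher number here means that more compound is tolerated, a lower number that less compound is tolerated), compound 1 gives > 244000 nM, which is a limit of the assay rather than a number. Compound 2 gives > 244000 nM in this assay, again a limit. The step that the two limits leave unreadable from compound 1 to compound 2 is therefore of unknown size, and the limit of > 244000 nM in this assay, at which 2 of the 2 values shown sit, shows both values resting at that same limit. Where compound 2 stands, then, is only known as a range at or beyond the top of the assay.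

Compound 3, `COc1cc(CC(O)c2ccc(-c3ccc(F)cc3)cc2)c([N+](=O)[O-])cc1OC`, differs from compound 2 by fluoro in place of methoxy on an aromatic carbon, that is, 4-methoxyphenyl to 4-fluorophenyl. For the measured compounds named here, no measured step touches a fluoro group, and the single measured step is unreadable, so nothing here points to a change beyond the scatter. Compound 3 is expected to show the step that the limit leaves unreadable from compound 2 to compound 3 in this assay, and most likely to return a limit again. The estimate for compound 3 is 300000 nM, within 150000 nM to 1000000 nM.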

Compound 3, half-maximal cytotoxic concentration: 4500 nM
For compound 3 the middle estimate is 67-fold (1.82 log units) above the measured one, and the stated range ends above it.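

In this assay, fluoro in place of methoxy on this aromatic carbon gives an at least 54-fold lower number from compound 2 to compound 3 (1.73 log units; beyond the scatter). This shows what compound 1 and compound 2 could not: a change at this position can strongly alter how much compound the cells tolerate. Fluoro in place of hydroxymethyl at the same place gives an at least 54-fold lower number from compound 1 to compound 3 (1.73 log units; beyond the scatter), and both sizes are only minimums, since the true steps could be larger given that the two earlier compounds rest on a limit: the limit of > 244000 nM in this assay, at which 2 of the 3 values shown sit.

The step between compound 1 and compound 2 cannot be read, so those two groups cannot be ranked against each other. Also open, on these data alone, is whether this sharp fall is particular to fluoro, or whether chloro, an amine or a carboxylic acid at this place would bring the same fall.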